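This account rests on a few compounds, and the source may have more. Where it says the series, first, only, none or still open, it means among the compounds named here.

Working notes on the series. In a functional assay on KB cells (Homo sapiens) for inhibition, read by sulforhodamine B assay (a lower number here means a stronger inhibitor of growth, a higher number a weaker inhibitor of growth), compound 1 `COc1ccc(-c2ccc(-c3ccc(-c4nc5ccccc5[nH]4)cc3)cc2)cc1` gives 47200 nM and compound 2 `Oc1ccc(-c2ccc(-c3ccc(-c4nc5c(O)cccc5[nH]4)cc3)cc2)cc1` gives 3190 nM. Compound 2 holds the lower of the two numbers, and the gap lies beyond the scatter. These two compounds differ in more than one place, so the gap cannot be assigned to any single change. Compound 3 `COc1ccc(-c2ccc(-c3ccc(-c4nc5c(O)cccc5[nH]4)cc3)cc2)cc1` departs from compound 2 in one place: methyl in place of hydrogen on an oxygen on an aromatic ring, or 4-hydroxyphenyl to 4-methoxyphenyl. Among the compounds with values here, no measured pair isolates this change. The 4-methoxyphenyl group is shared with compound 1, at 47200 nM, so a value between the two measured numbers, nearer compound 2, seems likely. In this assay the expected change is a 2.8-fold higher number from compound 2 to compound 3 (0.45 log units; beyond the scatter), a modest move toward weaker inhibition of growth, just beyond the scatter. The estimated value for compound 3 is 9000 nM, with an expected range of 3000 nM to 27000 nM.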

Compound 3, concentration for 50% growth inhibition: 4900 nM
Compound 3: middle estimate off by 1.8-fold (0.26 log units), on the high side; measured number inside the range.
By their numbers in this assay, from the lowest: compounds 2 and 3 (each within the scatter of the next); then compound 1.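

In this assay, methyl in place of hydrogen on this oxygen on an aromatic ring gives a 1.5-fold higher number from compound 2 to compound 3 (0.19 log units; within the scatter), so the 4-hydroxyphenyl and 4-methoxyphenyl groups are not told apart here. Within the data shown here, the other change now stands alone for the first time: with the 4-methoxyphenyl group held constant, hydroxy in place of hydrogen on an aromatic carbon gives a 9.6-fold lower number from compound 1 to compound 3 (0.98 log units; beyond the scatter). Among these compounds, of the two single changes, only this one moves the number beyond the scatter.

The compounds shown leave open whether a longer chain such as ethoxy or propoxy on the same oxygen would also leave the number within the scatter. They also leave open whether an amine or a methoxy could stand in for the hydroxy on the core. No measurement here accounts for the size of either step.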